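Chloro in Place of Amino: Expected Cytotoxicity of Compound 3

The compounds below may be only part of what the source reports. "The series", "measured", "known", "first", "only" and "open" are said of these compounds alone.

Measured compounds:
compound 1, `Nc1ccc(-c2nnc(SC3=CS(=O)(=O)c4ccccc43)o2)cc1`, gives 24000 nM
compound 2, `Cc1ccc(-c2nnc(SC3=CS(=O)(=O)c4ccccc43)o2)cc1`, gives 31000 nM

Both numbers come from an ADME assay on HepG2 cells (Homo sapiens) for cytotoxicity, read by fluorescence and resazurin assay, with a stated time of 24 h; on this read-out higher numbers stand for lower toxicity in this test and lower numbers for higher toxicity in this test. Compound 1 and compound 2 share one core and differ only in the group on one aromatic carbon, methyl in place of amino. The step of a 1.3-fold higher number from compound 1 to compound 2 (0.11 log units; within the scatter) lies within the scatter, so the two numbers sit together and neither compound can be called more or less toxic than the other in this assay. Within the data shown here, compound 1 is therefore one of two closely matched values, with compound 2 as its only neighbour.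

Compound 3, `O=S1(=O)C=C(Sc2nnc(-c3ccc(Cl)cc3)o2)c2ccccc21`, is not yet measured. It differs from compound 1 by chloro in place of amino on an aromatic carbon; the change sits on an aromatic carbon of a six-membered aromatic ring of carbon only, para to a large group, turning 4-aminophenyl into 4-chlorophenyl. Among the measured compounds shown here, the only step that bears on it is the one from compound 1 to compound 2, which also exchanged the amino group on that aromatic carbon and stayed within the scatter. The expected step of a 1.1-fold higher number from compound 1 to compound 3 (0.05 log units; within the scatter) is therefore none beyond the scatter. Compound 3 is estimated at 27000 nM, with a range from 11000 nM to 65000 nM.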

Compound 3, half-maximal cytotoxic concentration: 22000 nM
The estimate for compound 3 lay 1.2-fold (0.09 log units) above the measured number, and the stated range covers the measured number.
By their numbers in this assay, from the lowest: compounds 3, 1 and 2 (each within the scatter of the next).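

At this aromatic carbon, para to a large group, a third group now stands alongside amino and methyl, and the step of a 1.1-fold lower number from compound 1 to compound 3 (0.04 log units; within the scatter) for chloro in place of amino and the step of a 1.4-fold lower number from compound 2 to compound 3 (0.15 log units; within the scatter) for chloro in place of methyl both leave the compounds unseparated in this assay on this read-out. The first of these steps also shows that amino, which carries a hydrogen-bond donor and a hydrogen-bond acceptor, can give way to chloro, which carries neither, without any step beyond the scatter. Nothing available gives a reason for these close numbers.

The compounds shown leave open whether a group of another kind on this carbon, such as a carboxylic acid, a nitrile or a longer chain like butyl, would give a step beyond the scatter, so the close numbers describe amino, methyl and chloro only. They also leave open whether the same exchanges would stay this quiet elsewhere on the ring, or whether changes to the shared core would move the number, since all three compounds differ only at this one place.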